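Amide substituent and cytotoxicity in a furan-ring series

The source may report more compounds than this note shows. Statements on the series, on what has been measured and on what is new or still open speak of the compounds shown alone.

Measured so far:
- compound 1, `C=CC1=C(C(=O)NC2CCCCC2)C(c2ccc(OC)cc2)OC1`: > 100000 nM
- compound 2, `C=CC1=C(C(=O)NCC(C)C)C(c2ccc(OC)cc2)OC1`: > 100000 nM
- compound 3, `C=CC1=C(C(=O)NCc2ccc(C)cc2)C(c2ccc(OC)cc2)OC1`: 31700 nM

In a functional assay on SW480 cells (Homo sapiens) for cytotoxicity, read by MTT assay, with a stated time of 24 h (a lower number here means a stronger inhibitor, a higher number a weaker inhibitor), compound 1 reaches only the limit of the assay, > 100000 nM, not a number. Compound 2 likewise returns a limit, > 100000 nM. Going by the values given here, compound 3 is the only member with a read number, 31700 nM, and so it stands as the sole fixed point of the set; the step that the two limits leave unreadable from compound 1 to compound 2 cannot be read from two limits, whereas an at least 3.1-fold lower number from compound 1 to compound 3 (0.49 log units; beyond the scatter) and an at least 3.1-fold lower number from compound 2 to compound 3 (0.49 log units; beyond the scatter) both point the same way, with both aliphatic substituents sitting at the limit of > 100000 nM in this assay, at which 2 of the 3 values shown sit.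

Compound 4, `C=CC1=C(C(=O)Nc2ccccc2OC)C(c2ccc(OC)cc2)OC1`, is the next case: 2-methoxyphenyl in place of 4-methylbenzyl on an amide-type nitrogen. Among the compounds with values here, the steps that bear on it, an at least 3.1-fold lower number from compound 1 to compound 3 (0.49 log units; beyond the scatter) and an at least 3.1-fold lower number from compound 2 to compound 3 (0.49 log units; beyond the scatter), only separate an aromatic-ring substituent from purely saturated ones; no measured pair separates one aromatic-ring substituent from another, nor an aryl joined directly to the nitrogen from a benzyl. Since compound 4 keeps a six-membered aromatic ring on the amide nitrogen, the expected step of a 1.1-fold higher number from compound 3 to compound 4 (0.04 log units; within the scatter) is small and not beyond the scatter. In this assay compound 4 is therefore expected to give about 35000 nM, within 12000 nM to 100000 nM, with a real chance that only a limit is returned.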

Compound 4, half-maximal inhibitory concentration: > 100000 nM
Compound 4 gave a limit, no number; the forecaster's own chance of this, stated with the estimate: 35%; middle value at least 2.8-fold (0.45 log units) away from the limit.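

In this assay, an aromatic ring on the amide nitrogen does not by itself secure a read number: replacing 4-methylbenzyl with 2-methoxyphenyl gives an at least 3.1-fold higher number from compound 3 to compound 4 (0.49 log units; beyond the scatter), although both groups carry one six-membered aromatic ring of carbon only. The earlier steps shown here set compound 3 only against saturated substituents, whereas this pair shows that the position also distinguishes between two aromatic substituents. The steps from compound 1 and from compound 2 to compound 4 cannot be read, and compound 3 remains the only member with a read number, the others sharing one limit: the limit of > 100000 nM in this assay, at which 3 of the 4 values shown sit.

Compound 4 differs from compound 3 both in having its aryl ring joined directly to the amide nitrogen and in the substituent on that ring, and the compounds shown do not separate these two changes. On these data alone, an unsubstituted phenyl or a 4-methoxybenzyl group on the same nitrogen would bear on that question, while how far compound 1, compound 2 and compound 4 differ from one another remains open.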